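Swapping an N-ethyl for an N-phenyl on the piperazine

A few compounds are considered here, and "the series" means these few. Any claim that something is new, unique, unknown or untested is made for them only; others in the source may bear on it.

Compound 2 `CCN1CCN(c2nc(N)c3cc(OC)c(OC)cc3n2)CC1` holds the lowest of the two numbers, giving 0.0389 nM in an assay on thoracic aorta (strain Wistar) for antagonist activity at Adrenergic receptor alpha-1 (Rattus norvegicus), with a stated time of 30 min; on this read-out lower numbers stand for tighter binding and higher numbers for weaker binding; compound 1 `COc1cc2nc(N3CCN(C)CC3)nc(N)c2cc1OC` gives 0.589 nM. Compound 3 `COc1cc2nc(N3CCN(c4ccccc4)CC3)nc(N)c2cc1OC` differs from compound 2 by phenyl in place of ethyl on an amine nitrogen in a ring. Among the compounds with values here, the only measured step at this position, a 15-fold lower number from compound 1 to compound 2 (1.18 log units; beyond the scatter), shows that a larger group on that ring nitrogen lowered the number. Phenyl is larger again, but no measured step covers an aromatic group there, so the direction is uncertain. Compound 3 is therefore expected near 0.12 nM, within 0.01 nM to 1.5 nM, a step of a 3.1-fold higher number from compound 2 to compound 3 (0.49 log units; beyond the scatter).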

Compound 3, dissociation constant: 1.82 nM
Compound 3: the middle estimate sits 15-fold (1.18 log units) below what was measured, and the stated range ends below it.
By their numbers in this assay, from the lowest: compound 2; then compound 1; then compound 3.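

The number on the ring nitrogen does not simply fall as the group there grows: phenyl in place of ethyl gave a 47-fold higher number from compound 2 to compound 3 (1.67 log units; beyond the scatter), so the fall seen from methyl to ethyl did not extend to an aromatic ring. Phenyl also ends up on the far side of methyl, with a 3.1-fold higher number from compound 1 to compound 3 (0.49 log units; beyond the scatter), which leaves compound 3 with the highest number of the three in this assay. Nothing measured here accounts for this reversal. From the compounds shown here alone, what a propyl chain or a benzyl group on that nitrogen would give stays open, so it cannot yet be said whether the aromatic ring itself or the larger count of heavy atoms goes with the higher number.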